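Compound 3 to compound 4: isobutyl to isopentyl

This account rests on a few compounds, and the source may have more. Where it says the series, first, only, none or still open, it means among the compounds named here.

Measured in an ADME assay on Huh-7 cells (Homo sapiens) for cytotoxicity, with a stated time of 72 h (a lower number here means that less compound is tolerated, a higher number that more compound is tolerated), each value a limit of the assay:
Compound 1 (`CC(C)CCn1nc(-c2ccccc2)c(O)c(C2=NS(=O)(=O)c3cc(NS(C)(=O)=O)ccc3N2)c1=O`) gives > 1000 nM
Compound 2 (`CC(C)CCn1nc(C2CCC2)c(O)c(C2=NS(=O)(=O)c3cc(NS(C)(=O)=O)ccc3N2)c1=O`) gives > 33000 nM
Compound 3 (`CC(C)CCn1nc(CC(C)C)c(O)c(C2=NS(=O)(=O)c3cc(NS(C)(=O)=O)ccc3N2)c1=O`) gives > 1000 nM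

Compound 3 stands at > 1000 nM as a limit and not a number. This is the limit of > 1000 nM in this assay, at which 2 of the 3 values shown sit, and it gives compound 3 no exact place in the series. Compound 2 sits at the limit of > 33000 nM in this assay, at which 1 of the 3 values shown sits, and that too is only a limit.

Compound 4 (`CC(C)CCc1nn(CCC(C)C)c(=O)c(C2=NS(=O)(=O)c3cc(NS(C)(=O)=O)ccc3N2)c1O`) differs from compound 3 by one change (isobutyl in place of isopropyl on a saturated chain carbon bound to an aromatic carbon) with isobutyl in place of isopropyl on a saturated chain carbon bound to an aromatic carbon. Cut one bond further out, this reads isobutyl to isopentyl.

Three measured steps exchange groups on an aromatic carbon: a step that the two limits leave unreadable from compound 1 to compound 2 and a step that the two limits leave unreadable from compound 1 to compound 3 and a step that the two limits leave unreadable from compound 2 to compound 3 in turn. They give no size and no direction, so no particular step is expected in this assay and compound 4 is expected to return a limit as well. The middle of the estimate is set upward of the limit of compound 3 because compound 2 reaches > 33000 nM as a limit. The expected step is a step that the limit leaves unreadable from compound 3 to compound 4 as an estimate taken from a limit only. For compound 4 the estimated value is 10000 nM and the expected range runs from 2000 nM to 50000 nM.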

Compound 4, half-maximal cytotoxic concentration: > 33000 nM
Compound 4 was reported as a limit (the forecaster's own chance of this, stated with the estimate: 85%); at least 3.3-fold (0.51 log units) between middle value and limit.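

In this assay, among these compounds, compound 4 stands only as a limit, as do compound 1, compound 2 and compound 3, so no step to compound 4 from any of them can be read. The compounds shown leave open the size and direction of any effect of exchanging these groups on tolerated concentration.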